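The source may report more compounds than this note shows. Statements on the series, on what has been measured and on what is new or still open speak of the compounds shown alone.

Compound 1 `CCn1c(C(=O)NCCN)ccc1C(CC)(CC)c1ccc(OCCC(O)(CC)CC)c(C)c1` is the only one of the three measured compounds that yields a number in an ADME assay on L02 cells (Homo sapiens) for antiproliferative activity, read by MTT assay, with a stated time of 48 h; on this read-out lower numbers stand for stronger inhibition and higher numbers for weaker inhibition: in this assay compound 1 gives 2940 nM. Compound 2 `C#CCCOC(=O)c1ccc(C(CC)(CC)c2ccc(OCCC(O)(CC)CC)c(C)c2)n1CC` reaches only a limit of the assay, > 50000 nM. Compound 3 `CCOc1ccc(NC(=O)c2ccc(C(CC)(CC)c3ccc(OCCC(O)(CC)CC)c(C)c3)n2CC)cc1` likewise sits at a limit, > 50000 nM. Both departures from compound 1 are therefore read against (the limit of > 50000 nM in this assay, at which 2 of the 3 values shown sit). The step of an at least 17-fold higher number from compound 1 to compound 2 (1.23 log units; beyond the scatter) and the step of an at least 17-fold higher number from compound 1 to compound 3 (1.23 log units; beyond the scatter) are both large and both beyond the scatter, while the step that the two limits leave unreadable from compound 2 to compound 3 cannot be sized, since both ends are limits.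

Compound 4 `CCC(C)C(NC(=O)c1ccc(C(CC)(CC)c2ccc(OCCC(O)(CC)CC)c(C)c2)n1CC)C(=O)O` has not yet been measured. It differs from compound 1 at the amide nitrogen: 1-carboxy-2-methylbutyl in place of 2-aminoethyl on an amide-type nitrogen. The step from compound 1 to compound 3 bears most directly on this change, because it also replaced the 2-aminoethyl on that nitrogen and gave an at least 17-fold higher number from compound 1 to compound 3 (1.23 log units; beyond the scatter); the step to compound 2, which also lost the 2-aminoethyl group, went the same way. He therefore expects a large rise, a 10-fold higher number from compound 1 to compound 4 (1.01 log units; beyond the scatter), with a fair chance that only a limit is reported. His estimate for compound 4 in this assay is 30000 nM, within a range of 8000 nM to 100000 nM.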

Compound 4, half-maximal inhibitory concentration: 9990 nM
Beside the measured number, compound 4's estimate is 3.0-fold (0.48 log units) above it; the range from low to high includes it.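

In this assay, the amide-type nitrogen turns out not to depend on 2-aminoethyl for a measurable value: with 1-carboxy-2-methylbutyl in its place the result is a 3.4-fold higher number from compound 1 to compound 4 (0.53 log units; beyond the scatter), a modest step, beyond the scatter but far smaller than the earlier departures suggested. What enters at this position therefore matters, since replacing 4-ethoxyphenyl on that nitrogen gives an at least 5.0-fold lower number from compound 3 to compound 4 (0.69 log units; beyond the scatter), and (1-carboxy-2-methylbutyl)amino in place of (but-3-yn-1-yl)oxy on the carbonyl carbon gives an at least 5.0-fold lower number from compound 2 to compound 4 (0.69 log units; beyond the scatter), both sized only from one end that is a limit, so that their true size may be larger. Among the departures from compound 1, compound 4 alone yields a number rather than a limit: the limit of > 50000 nM in this assay, at which 2 of the 4 values shown sit.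

The compounds shown leave open which part of 1-carboxy-2-methylbutyl accounts for this, the carboxylic acid or the branched carbon chain, and a plain branched alkyl chain without the acid, or a short carboxymethyl group, on the same nitrogen would separate the two. They also leave open whether an amine at the end of a longer chain would keep the value of compound 1 or move it.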